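This account rests on a few compounds, and the source may have more. Where it says the series, first, only, none or still open, it means among the compounds named here.

Compound 1 `O=C(NCc1ccccc1)c1nc(Cc2ccccc2C(F)(F)F)[nH]c(=O)c1O` — in this assay, a value that is a limit: > 100000 nM
Compound 2 `CN(Cc1ccccc1)C(=O)c1nc(Cc2ccccc2C(F)(F)F)n(C)c(=O)c1O` — a limit as well: > 100000 nM
Compound 3 `Cn1c(Cc2ccccc2)nc(C(=O)NCc2ccccc2)c(O)c1=O` — again a limit: > 100000 nM

The measurements come from an ADME assay on HepG2 cells (Homo sapiens) for cytotoxicity, in the presence of a further agent that is not named here; a lower number here means a stronger inhibitor, a higher number a weaker inhibitor. Compound 2 gives no number there, only a limit, and it is not alone in this: compound 2 stands at the limit of > 100000 nM in this assay, at which 3 of the 3 values shown sit. Among the measured compounds shown here, compound 1 and compound 3 rest on the same limit, so no ordering among the three is possible and no step between measured compounds can be read.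

Compound 4 `Cn1c(Cc2ccccc2C(F)(F)F)nc(C(=O)NCc2ccccc2)c(O)c1=O` is the compound still to be measured. It differs from compound 2 in one place: hydrogen in place of methyl on an amide-type nitrogen. For the measured compounds named here, with no measured step to lean on, the expectation rests on the fact that compound 2 sits at the limit of > 100000 nM in this assay, at which 3 of the 3 values shown sit, and the expected step from compound 2 to compound 4 is a step that the limit leaves unreadable from compound 2 to compound 4, that is, nothing beyond the usual scatter. Compound 4 is therefore estimated at 200000 nM, with a range from 50000 nM to 1000000 nM, and it is expected that this assay will again report only a limit.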

Compound 4, half-maximal inhibitory concentration: > 100000 nM
Compound 4 was reported as a limit; the forecaster's own chance of this, stated with the estimate: 85%; the middle value does not contradict the limit.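

Compound 4 rests on the same limit as compound 1, compound 2 and compound 3 in this assay, so no step to compound 4 can be read: the limit of > 100000 nM in this assay, at which 4 of the 4 values shown sit.

The compounds shown leave open whether any of these single changes affects the result in this assay, as none of the four gives a number.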